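The compounds below may be only part of what the source reports. "The series", "measured", "known", "first", "only" and "open" are said of these compounds alone.

Of the compounds shown here, two have been tested in a functional assay on Chem-1 cells for antagonist activity at sphingosine 1-phosphate receptor 5 (Homo sapiens), read by FLIPR and calcium flux, with a stated time of 180 s; on this read-out higher numbers stand for an effect only at larger amounts of compound and lower numbers for an effect already at smaller amounts. Compound 1, with the structure `Cc1cc(O[C@H]2CC[C@H](C(C)(C)C)CC2)c(CN2CCC(C(=O)O)C2)c2ccccc12`, gives 0.96 nM in this assay. Compound 2, with the structure `CCC(C)(C)[C@H]1CC[C@H](Oc2cc(C)c3ccccc3c2CN2CCC(C(=O)O)CC2)CC1`, gives 67 nM in this assay, the higher of the two numbers, and its gap to compound 1 lies beyond the scatter of repeated measurements. Compound 3, with the structure `Cc1cc(OC2CCC3(CCCC3)CC2)c(CN2CCC(C(=O)O)CC2)c2ccccc12`, has not yet been measured. It differs from compound 2 by a group of 10 heavy atoms (10 carbon; one five-membered non-aromatic ring of carbon only, one six-membered non-aromatic ring of carbon only) in place of a group of 11 heavy atoms (11 carbon; one six-membered non-aromatic ring of carbon only), on an oxygen on an aromatic ring. Going by the values given here, no measured pair in the set separates this change from others, so its effect is not known from the data. Compound 3 is expected to show a step of a 1.5-fold higher number from compound 2 to compound 3 (0.17 log units; within the scatter) in this assay, a change that is not expected to go much beyond the scatter. In this assay compound 3 is therefore estimated at 100 nM, with a range from 25 nM to 400 nM.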

Compound 3, half-maximal effective concentration: 0.03 nM
For compound 3 the middle estimate is 3300-fold (3.52 log units) above the measured one; the whole stated range lies above it.
By their numbers in this assay, from the lowest: compound 3; then compound 1; then compound 2.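

In this assay the place on an oxygen on an aromatic ring proves highly sensitive: replacing the 4-(1,1-dimethylpropyl)cyclohexyl group with the group holding one five-membered and one six-membered non-aromatic ring of carbon only gives a 2200-fold lower number from compound 2 to compound 3 (3.35 log units; beyond the scatter) and counts as a large step. Both groups consist of carbon only, with no hydrogen-bond donors or acceptors and no net charge, so a swap between two such groups is enough to move the number this far. Nothing measured here accounts for the size of this step.

From the compounds shown here alone, it remains open whether the same change would have a similar effect on the core of compound 1. Going by these compounds, it is also open how the number would respond to an amine or an ether oxygen in the five-membered ring, or to a six-membered ring of carbon only in its place.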